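The source may hold more compounds than are shown below. What is called first, only, known or untested is meant among the compounds shown, and "the series" means these compounds.

Measured compounds and their numbers:

compound 1 `CCCCCCCCC(=O)N1c2ccccc2CCC1C(=O)Nc1ccccc1C(F)(F)F` — 6180 nM
compound 2 `CCCCCCCCC(=O)N1c2ccccc2CCC1C(=O)Nc1ccccc1O` — 31100 nM
compound 3 `O=C(Nc1ccccc1O)C1CCc2ccccc2N1C(=O)c1ccccc1` — 3780 nM

These numbers come from a functional assay on NUGC-3 cells (Homo sapiens) for cytotoxicity, read by sulforhodamine B assay, with a stated time of 72 h; on this read-out higher numbers stand for weaker inhibition of growth and lower numbers for stronger inhibition of growth. Among the three, compound 1 stands second highest: compound 3 lies within the scatter of it, whereas compound 2 is clearly apart, as the step of a 5.0-fold higher number from compound 1 to compound 2 (0.70 log units; beyond the scatter) shows.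

Compound 4 `O=C(Nc1ccccc1C(F)(F)F)C1CCc2ccccc2N1C(=O)c1ccccc1Cl` has not yet been measured. It differs from compound 1 in one place: 2-chlorophenyl in place of octyl on a carbonyl carbon. Among the compounds with values here, no measured pair makes this exact change, but the step of an 8.2-fold lower number from compound 2 to compound 3 (0.92 log units; beyond the scatter) swaps the same octyl for a phenyl on the same carbonyl carbon, in the hydroxy-bearing pair, and the number falls well beyond the scatter. Within the data shown here, a change of similar kind is therefore expected in this assay, a drop, though with a wide range since only one pair speaks to it and the entering group here carries a chlorine.

Compound 4 is expected to give about 1000 nM, within 300 nM to 4000 nM. The expected step is a 6.2-fold lower number from compound 1 to compound 4 (0.79 log units; beyond the scatter).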

Compound 4, concentration for 50% growth inhibition: 2730 nM
For compound 4 the middle estimate is 2.7-fold (0.44 log units) below the measured one, within the range that was stated.
By their numbers in this assay, from the lowest: compounds 4, 3 and 1 (each within the scatter of the next, the first and the last beyond it); then compound 2.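

In this assay, 2-chlorophenyl in place of octyl on the carbonyl carbon gives a 2.3-fold lower number from compound 1 to compound 4 (0.35 log units; beyond the scatter). A drop on swapping octyl for an aromatic ring at this place therefore no longer rests on the hydroxy-bearing pair alone, with its an 8.2-fold lower number from compound 2 to compound 3 (0.92 log units; beyond the scatter): it also appears in a compound carrying trifluoromethyl, so the direction holds in both pairs shown. No measurement shown here accounts for this drop.

On these data alone, whether the chlorine itself contributes stays open: compound 3 and compound 4 differ in more than one place, so they cannot be compared directly. Also open, as far as these compounds go, is how an amine or a carboxylic acid at this place, or a chain shorter or longer than octyl on the same carbonyl carbon, would behave.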